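Series notes: chain between amine and aryl ether

A few compounds are considered here, and "the series" means these few. Any claim that something is new, unique, unknown or untested is made for them only; others in the source may bear on it.

Two members of this series have been measured so far. Compound 1 `CCCCN(CCCC)CCCOc1ccc(S(=O)(=O)c2c(CCC)cn3ccccc23)cc1` gives 54.3 nM in a functional assay (aorta) with Rattus norvegicus as the target; on this read-out lower numbers stand for stronger inhibition and higher numbers for weaker inhibition. Compound 2 `CCCCN(CCCC)CCCOc1ccc(S(=O)(=O)c2c(CC)cn3ccccc23)cc1` gives 31.3 nM in the same assay. For the measured compounds named here, the only measured step, a 1.7-fold lower number from compound 1 to compound 2 (0.24 log units; within the scatter), changes the alkyl on the core; compound 2 stands at the lower of the two numbers, but that step is within the scatter, so the two compounds cannot be ranked against each other.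

Compound 3 `CCCCN(CCCC)CCCCOc1ccc(S(=O)(=O)c2c(CC)cn3ccccc23)cc1` is not yet measured. It differs from compound 2 by (dibutylamino)methyl in place of dibutylamino on a saturated chain carbon, three bonds along the chain from an oxygen on an aromatic ring; the same difference, cut one bond further out, reads (dibutylamino)methyl to 2-(dibutylamino)ethyl. Going by the values given here, no measured step touches this part of the molecule: the step from compound 1 to compound 2 concerns the alkyl on the core, not the chain carrying the dibutylamino group, and gives no guidance here.

With nothing bearing on the change, the expectation is a step of a 1.1-fold higher number from compound 2 to compound 3 (0.05 log units; within the scatter), that is, none beyond the scatter. Going by these compounds, compound 3 is therefore estimated at 35 nM in this assay, within a range of 12 nM to 100 nM, the width reflecting that the change is untested.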

Compound 3, half-maximal inhibitory concentration: 33.3 nM
For compound 3 the middle estimate is 1.1-fold (0.02 log units) above the measured one; the range from low to high includes it.
By their numbers in this assay, from the lowest: compounds 2, 3 and 1 (each within the scatter of the next).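

For the compounds shown here, the change of dibutylamino to (dibutylamino)methyl, on a saturated chain carbon, three bonds along the chain from an oxygen on an aromatic ring, gives the first reading on the chain carrying the amine in this assay: a 1.1-fold higher number from compound 2 to compound 3 (0.03 log units; within the scatter). For this pair, the longer chain between the amine and the aryl ether therefore brings no change beyond the scatter, and compound 2 and compound 3 cannot be ranked against each other. No available evidence bears on this result.

Going by these compounds, only these two chain lengths are compared, so it remains open whether 2-(dibutylamino)ethyl at the same place, a still longer chain, or a shorter chain ending in the same amine would also stay within the scatter. Also open, on these data alone, are a cyclic amine such as piperidine or a smaller one such as dimethylamino in place of dibutylamino, and whether a propyl group on the core, as in compound 1, would read the same when combined with the longer chain of compound 3.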